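The source may report more compounds than this note shows. Statements on the series, on what has been measured and on what is new or still open speak of the compounds shown alone.

Measured compounds:
compound 1 `CN(C)c1cccc(Oc2ccc3c(NCCCNCc4ccco4)ccnc3c2)c1`, 9.28
compound 2 `Fc1ccc(Oc2ccc3c(NCCCNCc4ccco4)ccnc3c2)cc1`, 9.28
compound 3 `COc1cccc(CNCCCNc2ccnc3cc(Oc4cccc(N(C)C)c4)ccc23)c1O`, 9.28

In a physicochemical assay for acid dissociation, compound 1 gives 9.28. Compound 2 differs from it by 4-fluorophenyl in place of 3-(dimethylamino)phenyl on an oxygen on an aromatic ring, and the step is no change at the digits printed from compound 1 to compound 2 (within the scatter). Compound 3 carries a different core, the difference being (2-hydroxy-3-methoxyphenyl in place of furan-2-yl on a saturated chain carbon bound to an amine nitrogen); that step is no change at the digits printed from compound 1 to compound 3 (within the scatter). Compound 3 thus stands level with compound 1 and compound 2 at the digits recorded, and none of the three pairs moves beyond the scatter of this assay.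

Compound 4 `COc1cccc(CNCCCNc2ccnc3cc(Oc4ccc(F)cc4)ccc23)c1O` has not been measured. It differs from compound 3 by 4-fluorophenyl in place of 3-(dimethylamino)phenyl on an oxygen on an aromatic ring. This is the same change as that from compound 1 to compound 2: the groups that leave and enter are the same, and the place is the same word for word, an oxygen on an aromatic ring whose other neighbours are aromatic carbon. The two cases differ only in the core on which the change is made, and that core difference, as seen from compound 1 to compound 3, left this assay unmoved.

The expected step for compound 4 is therefore no change at the digits printed from compound 3 to compound 4 (within the scatter), set beside no change at the digits printed from compound 1 to compound 2 (within the scatter), because the same change on the core of compound 1 gave no change at the digits printed from compound 1 to compound 2 (within the scatter). Compound 4 is estimated at 9.28, with the expected range running from 9 to 9.55.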

Compound 4, acid dissociation constant: 9.28
Estimate against measurement, compound 4: no gap at the digits printed, within the range that was stated.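

In this assay, 4-fluorophenyl in place of 3-(dimethylamino)phenyl on an oxygen on an aromatic ring gives no change at the digits printed from compound 3 to compound 4 (within the scatter) and, on the core of compound 1, no change at the digits printed from compound 1 to compound 2 (within the scatter) on the same terms, while the core difference read with 4-fluorophenyl in place gives no change at the digits printed from compound 2 to compound 4 (within the scatter) and so closes the square of four compounds without any step beyond the scatter. Going by these compounds alone, this shows that the change reads the same on these two cores in this one read-out, but it does not show that a step of real size would carry from one core to the other, since both steps are null and no step here tests that, nor does it extend to any core outside these four compounds. Nothing measured here bears on why the four compounds stand level.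

The compounds shown leave open whether a carboxylic acid or a morpholine in place of the 4-fluorophenyl would shift this assay on either core. They also leave open whether a longer chain on the amine nitrogen, or a third core carrying the same change, would keep the four-compound agreement.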